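The compounds below may be only part of what the source reports. "The series", "measured", "known", "first", "only" and "open" are said of these compounds alone.

Measured so far in a functional assay for inhibition of Polyunsaturated fatty acid 5-lipoxygenase (Homo sapiens); a higher number here means a weaker inhibitor, a lower number a stronger inhibitor:
compound 1 `C=CCC(O/N=C(\C)C(=O)O)c1ccc(OCc2ccc3ccccc3n2)cc1`: 142 nM
compound 2 `O=C(O)/C=N/OC(c1ccc(CCc2ccc3ccccc3n2)cc1)C1CCCCC1`: 290 nM
compound 3 `C/C(=N\OC(c1ccc(OCc2ccc3ccccc3n2)c(C)c1)C1CCCCC1)C(=O)O`: 20 nM

Compound 3 holds the lowest of the three numbers in this assay. Compound 1 and compound 2 both sit at higher values, and the gap to each lies beyond the usual scatter, so compound 3 is the strongest inhibitor of the three measured. Compound 4 `C/C(=N\OC(c1ccc(OCc2ccc3ccccc3n2)c(Cl)c1)C1CCCCC1)C(=O)O` has not been measured. It differs from compound 3 by chloro in place of methyl on an aromatic carbon. Among the measured compounds shown here, no measured pair carries this exchange, so there is no observed step to lean on. The step from compound 3 to compound 4 is expected to be a 1.3-fold higher number from compound 3 to compound 4 (0.10 log units; within the scatter), small and not clearly beyond the scatter in either direction. Compound 4 is estimated at 25 nM, with a range of 8 nM to 70 nM.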

Compound 4, half-maximal inhibitory concentration: 27 nM
Estimate against measurement, compound 4: 1.1-fold (0.03 log units) below; low and high end bracket the measured number.
By their numbers in this assay, from the lowest: compounds 3 and 4 (each within the scatter of the next); then compound 1; then compound 2.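

In this assay, among the compounds shown here, chloro in place of methyl on this aromatic carbon gives a 1.4-fold higher number from compound 3 to compound 4 (0.13 log units; within the scatter), the first exchange made in one place only. The position therefore takes either group with no change that can be told from the scatter, so the low number of compound 3 does not depend on methyl alone. Nothing measured here bears on why the two groups read alike.

Open, as far as these compounds go, is how a methoxy, a fluoro or a trifluoromethyl group would read at this position. A longer chain such as ethyl also remains to be placed there.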